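The compounds below may be only part of what the source reports. "The series", "measured", "known", "first", "only" and "open" are said of these compounds alone.

Of the compounds shown here, three have been measured so far in a functional assay on WM 266-4 cells (Homo sapiens) for inhibition, read by MTT assay, with a stated time of 24 h; a lower number here means a stronger inhibitor of growth, a higher number a weaker inhibitor of growth. Compound 1 `O=C(c1ccc2c(c1)OCCO2)N1N=C(c2ccccc2)CC1c1ccccc1F` gives 2500 nM. Compound 2 `COc1ccc(C2=NN(C(=O)C3COc4ccccc4O3)C(c3ccc(F)cc3)C2)cc1` gives 6190 nM, and compound 3 `O=C(C1COc2ccccc2O1)N1N=C(c2ccccc2)CC1c1ccc(F)cc1` gives 3270 nM. Among these three numbers compound 1 stands lowest, with compound 3 close to it, within the scatter, and compound 2 further off, beyond it. For the measured compounds named here, the one step between measured compounds that differ in a single place is a 1.9-fold lower number from compound 2 to compound 3 (0.28 log units; within the scatter), a removal of a methoxy group from an aromatic ring.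

Compound 4 `O=C(c1ccc2c(c1)OCCO2)N1N=C(c2ccccc2)CC1c1ccccc1` has not yet been measured. It differs from compound 1 by hydrogen in place of fluoro on an aromatic carbon. Going by the values given here, no measured pair shows this exact change, so the step from compound 2 to compound 3 is the only guide: there, taking a small group off an aromatic ring left the number within the scatter. Removing the fluoro from compound 1 is a comparably small change, and a step of similar size in this assay is expected, with no clear direction. On that basis the estimate for compound 4 is 3000 nM, in the range from 1200 nM to 7500 nM, which corresponds to an expected step of a 1.2-fold higher number from compound 1 to compound 4 (0.08 log units; within the scatter).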

Compound 4, concentration for 50% growth inhibition: 1370 nM
The estimate for compound 4 lay 2.2-fold (0.34 log units) above the measured number; low and high end bracket the measured number.
By their numbers in this assay, from the lowest: compounds 4, 1, 3 and 2 (each within the scatter of the next, the first and the last beyond it).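

In this assay, the swap of 2-fluorophenyl to phenyl gives a 1.8-fold lower number from compound 1 to compound 4 (0.26 log units; within the scatter), so at this place, on an aromatic carbon ortho to a large group, the fluoro can be replaced by hydrogen without a step that stands out from the usual scatter of repeated measurements. For the compounds shown here, the earlier pair spoke only to a methoxy group on a different aromatic ring, so this is the first direct reading for the ring that carries the fluoro, and the second single change to stay within the scatter. For this one change, then, compound 1 and compound 4 cannot be told apart, and the fluoro shows no measurable contribution to growth inhibition here; no other data shown bear on what lies behind this result.

Fluoro and hydrogen are only two small options, so the compounds shown leave open whether a larger or charged group at this place, such as a trifluoromethyl, a dimethylamino group or a carboxylic acid, would produce a step beyond the scatter. They also leave open whether this flat response holds for any group other than fluoro on this ring.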